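The source may report more compounds than this note shows. Statements on the series, on what has been measured and on what is new or still open speak of the compounds shown alone.

Working notes on the series. Within the data shown here, in a functional assay on PC-3 cells (Homo sapiens) for antiproliferative activity, read by MTT assay, with a stated time of 48 h (on this read-out lower numbers stand for stronger inhibition and higher numbers for weaker inhibition), two compounds have numbers so far. Compound 1 (`COc1cccc2ccc(CNCc3ccc(/C=C/C(=O)NO)cc3)nc12`) gives 4600 nM in this assay and compound 2 (`COc1ccc2nc(CNCc3ccc(/C=C/C(=O)NO)cc3)ccc2c1`) gives 3700 nM there. These two values lie within the scatter of each other, so compound 2 stands level with compound 1 and neither can be ranked on these data.

The next compound is compound 3 (`O=C(/C=C/c1ccc(CNCc2ccc3cc(Cl)ccc3n2)cc1)NO`), which has chloro in place of methoxy on an aromatic carbon of compound 2: chloro in place of methoxy on an aromatic carbon is the whole difference between them. Among the measured compounds shown here, the series offers no measured pair that shows what this replacement does, so the expectation has only compound 2 at 3700 nM as its anchor, and the data give no ground for a direction. Expected is a 1.2-fold lower number from compound 2 to compound 3 (0.06 log units; within the scatter) and thus nothing beyond the scatter. For the measured compounds named here, the range is kept wide since no measured step supports it. In this assay compound 3 is estimated at 3200 nM within an expected range of 1300 nM to 8000 nM for this measurement.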

Compound 3, half-maximal inhibitory concentration: 4350 nM
For compound 3 the middle estimate is 1.4-fold (0.13 log units) below the measured one; the measured number falls inside the stated range.
By their numbers in this assay, from the lowest: compounds 2, 3 and 1 (each within the scatter of the next).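

In this assay, among these compounds, the replacement of methoxy by chloro on an aromatic carbon gives a 1.2-fold higher number from compound 2 to compound 3 (0.07 log units; within the scatter) and is the first measured step at this position. On these two compounds, the position accepts chloro, with one heavy atom and no hydrogen-bond acceptor, in place of methoxy, with two heavy atoms and one hydrogen-bond acceptor, and the read-out shows no separation beyond the scatter. No measurement at hand bears on what lies behind this result.

Still open, going by these compounds, is whether any group at this position can move the number beyond the scatter, and an amine, a carboxylic acid or a longer chain such as ethoxy would each put that to the test. Also open, on these data alone, is how chloro behaves at the place that methoxy holds in compound 1, and whether the outcome there would match the one seen at this position.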